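A few compounds are considered here, and "the series" means these few. Any claim that something is new, unique, unknown or untested is made for them only; others in the source may bear on it.

Compound 1 `Cc1cc(C)c(NC(=O)N(Cc2ccc(-c3nnc(C)o3)cc2)C2CCCCCC2)c(C)c1` has been examined in a functional assay on a cell-free system (plasma) with sterol O-acyltransferase, Soat (Rattus norvegicus) as the target; a lower number here means that less compound is needed, a higher number that more compound is needed for the effect. In this assay compound 1 gives no exact number but only a limit, > 0.32 mg/kg, which is the limit of > 0.32 mg/kg in this assay, at which 1 of the 2 values shown sits. A second compound, compound 2 `CSc1cc(C)nc(SC)c1NC(=O)N(Cc1ccccc1)Cc1cccc(-c2ccnn2C)c1`, has been examined in this assay as well. In this assay compound 2 also gives only a limit, < 1 mg/kg, which is the limit of < 1 mg/kg in this assay, at which 1 of the 2 values shown sits. Among the compounds with values here, with both results limits rather than numbers, the two compounds cannot be set in order against each other, and no sized step between measured compounds is available.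

Compound 3 `Cc1cc(C)c(NC(=O)N(Cc2ccc(-n3nccn3)cc2)C2CCCCCC2)c(C)c1` has not yet been measured. It differs from compound 1 in a single place: 2H-1,2,3-triazol-2-yl in place of 5-methyl-1,3,4-oxadiazol-2-yl on an aromatic carbon. The group that leaves and the group that enters are both five-membered aromatic rings with three hetero atoms and three hydrogen-bond acceptors, and the change happens para to a large group. Within the data shown here, since no measured step is available to lean on, the expected step from compound 1 to compound 3 in this assay, a step that the limit leaves unreadable from compound 1 to compound 3, is small and within the scatter, in neither direction. Compound 3 is therefore estimated at 1 mg/kg in this assay, with a range from 0.3 mg/kg to 3 mg/kg.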

Compound 3, dose for half-maximal effect: > 1 mg/kg
Compound 3 was reported as a limit; the forecaster's own chance of this, stated with the estimate: 50%; the middle value lies on the limit itself.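

Compound 1 and compound 3 are both known in this assay only as limits, and the size of the step between them cannot be read. The compounds shown leave open whether putting 2H-1,2,3-triazol-2-yl in place of 5-methyl-1,3,4-oxadiazol-2-yl changes the dose needed at all, and if so, in which direction and by how much.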